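Tosyl in place of thiophenecarbonyl on the threonine amide series

This account rests on a few compounds, and the source may have more. Where it says the series, first, only, none or still open, it means among the compounds named here.

Compound 2 `CCCCCCCCCCCCCCNC(=O)[C@@H](NC(=O)c1cccs1)[C@@H](C)O` carries the (thiophen-2-yl)carbonyl group on the amine nitrogen and stands at the top of the numbers in a functional assay on SiHa cells (Homo sapiens) for cytotoxicity, read by MTT assay, with a stated time of 48 h (on this read-out lower numbers stand for stronger inhibition and higher numbers for weaker inhibition), where compound 2 gives 63000 nM. The free amine compound 1 `CCCCCCCCCCCCCCNC(=O)[C@@H](N)[C@@H](C)O` gives 11000 nM in this assay, and compound 3 `CCCCCCCCCCCCCCNC(=O)[C@@H](NC(=O)c1cc2ccccc2n1C)[C@@H](C)O` gives 26500 nM. Among the measured compounds shown here, the step of a 5.7-fold higher number from compound 1 to compound 2 (0.76 log units; beyond the scatter) and the step of a 2.4-fold lower number from compound 2 to compound 3 (0.38 log units; beyond the scatter) are the only two measured steps, and both are modest.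

Compound 4 `CCCCCCCCCCCCCCNC(=O)[C@@H](NS(=O)(=O)c1ccc(C)cc1)[C@@H](C)O` differs from compound 2 by (4-methylphenyl)sulfonyl in place of (thiophen-2-yl)carbonyl on an amine nitrogen. For the measured compounds named here, no measured pair shares this swap of an acyl group for a sulfonyl group on the amine nitrogen. Going by the values given here, the step of a 2.4-fold lower number from compound 2 to compound 3 (0.38 log units; beyond the scatter) is the closest precedent, showing that exchanging the group on that nitrogen moves this assay by a modest amount; the step of a 5.7-fold higher number from compound 1 to compound 2 (0.76 log units; beyond the scatter) shows that covering the nitrogen at all raised the number relative to compound 1. Taken together, a modest step is expected for compound 4, more likely downward than upward, but the direction is uncertain.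

Compound 4 is estimated at 40000 nM in this assay, within a range of 15000 nM to 100000 nM, which corresponds to an expected step of a 1.6-fold lower number from compound 2 to compound 4 (0.20 log units; within the scatter).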

Compound 4, half-maximal inhibitory concentration: 19200 nM
For compound 4 the middle estimate is 2.1-fold (0.32 log units) above the measured one; measured number inside the range.
By their numbers in this assay, from the lowest: compounds 1, 4 and 3 (each within the scatter of the next, the first and the last beyond it); then compound 2.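

Exchanging the acyl group on this nitrogen for a sulfonyl group matters in this assay: the change gives a 3.3-fold lower number from compound 2 to compound 4 (0.52 log units; beyond the scatter), a wider move than the earlier exchange of one acyl group for another, a 2.4-fold lower number from compound 2 to compound 3 (0.38 log units; beyond the scatter). The comparison with the free amine gives a 1.7-fold higher number from compound 1 to compound 4 (0.24 log units; within the scatter), whereas (thiophen-2-yl)carbonyl gave a 5.7-fold higher number from compound 1 to compound 2 (0.76 log units; beyond the scatter), so covering this nitrogen does not by itself carry the number beyond the scatter of compound 1, and the outcome depends on the group that enters. No measured evidence accounts for the difference between these two groups.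

The change in compound 4 replaces the carbonyl with a sulfonyl and the thiophene ring with a 4-methylphenyl ring together, so a 4-methylbenzoyl or (thiophen-2-yl)sulfonyl group on the same nitrogen would be needed to separate the two contributions. Also open, as far as these compounds go, is whether a smaller group such as methanesulfonyl stays level with compound 1, and whether any group on this nitrogen can take the number clearly below that of compound 1.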